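The compounds below may be only part of what the source reports. "The series", "measured", "known", "first", "only" and "open" are said of these compounds alone.

Measured so far:
Compound 1, `COc1ccc(S(=O)(=O)NC(=O)Nc2ccc(Cl)cc2)s1`, gives 100% in a functional assay on the whole organism (6C3HED cells, Mus musculus) for inhibition, at a dose of 300 mg/kg by the oral route; a higher number here means more inhibition at the dose given (going by the name of the read-out), a lower number less inhibition.
Compound 2, `CCc1ccc(S(=O)(=O)NC(=O)Nc2ccc(Cl)cc2)s1`, gives 89% in this assay.

On these two numbers compound 2 stands lowest; its nearest neighbour is compound 1, and the step of a number 11 percentage points lower from compound 1 to compound 2 (beyond the scatter) lies beyond the scatter. Compound 3, `CCc1ccsc1S(=O)(=O)NC(=O)Nc1ccc(Cl)cc1`, has not yet been measured. It differs from compound 2 in one place: 3-ethylthiophen-2-yl in place of 5-ethylthiophen-2-yl on a sulfonyl sulfur.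

Among the compounds with values here, no measured step bears directly on this change. Within the data shown here, the only step known, a number 11 percentage points lower from compound 1 to compound 2 (beyond the scatter), concerns a different group on the ring rather than the same atoms joined differently, so it offers no guide to the direction of the change from compound 2 to compound 3. With the size of that step as the only gauge, a modest movement in either direction, or none beyond the scatter, is expected. For compound 3 an inhibition of 80% is estimated, within 55% to 100%, an expected step of a number 9 percentage points lower from compound 2 to compound 3 (within the scatter).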

Compound 3, a percentage reported as inhibition, in the whole organism at one dose (the size of the read-out at that dose, not a potency): 25%
Compound 3: middle estimate off by 55 percentage points, on the high side; measured number outside the range, below it.
By their numbers in this assay, from the lowest: compound 3; then compound 2; then compound 1.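

Where the ethyl group sits on the ring matters greatly in this assay: with the same atoms joined differently, 3-ethylthiophen-2-yl in place of 5-ethylthiophen-2-yl on a sulfonyl sulfur gives a number 64 percentage points lower from compound 2 to compound 3 (beyond the scatter), a large step where the exchange of methoxy for ethyl had given only a modest one, a number 11 percentage points lower from compound 1 to compound 2 (beyond the scatter). The contrast with the methoxy compound is larger still, at a number 75 percentage points lower from compound 1 to compound 3 (beyond the scatter), although that step changes both the group and its place on the ring. No evidence is at hand to explain this loss of inhibition.

Going by these compounds, it remains open whether the loss is specific to ethyl or would also follow from a methyl, an amine or a carboxylic acid in its place. On these data alone, how a longer chain such as propyl would behave in either arrangement also remains open.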